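Extending the hydroxyalkyl chain on the core of compound 1

The compounds below may be only part of what the source reports. "The series", "measured", "known", "first", "only" and "open" are said of these compounds alone.

Of the compounds shown here, three sharing a common core have been tested in an ADME assay on microsomes from liver (Mus musculus, strain CD1) for metabolic stability, read by LC-MS, using NADPH, with a stated time of 60 min; on this read-out higher numbers stand for a longer-lived compound and lower numbers for a shorter-lived compound. Compound 1 `COc1ccc(Cn2c(-c3ccccc3)c(-c3ccccc3)c3c(=N)n(CCO)cnc32)cc1` gives 0.518 h. Compound 2 `COc1ccc(-c2c(-c3ccc(OC)cc3)n(Cc3ccccc3)c3ncn([C@@H]4CCCC[C@H]4O)c(=N)c23)cc1` gives 0.487 h, and compound 3 `N=c1c2c(-c3ccccc3)c(-c3ccccc3)n(Cc3ccccc3)c2ncn1C1CCN(Cc2ccccc2)CC1` gives 0.537 h. The three numbers lie within the scatter of one another, so compound 1 stands neither apart from nor distinguishable from the others; its nearest neighbour is compound 3 and the furthest from it is compound 2, both within the scatter.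

Compound 4 `COc1ccc(Cn2c(-c3ccccc3)c(-c3ccccc3)c3c(=N)n(CCCO)cnc32)cc1` has not yet been measured in this assay. Relative to compound 1 the structures differ as follows: hydroxymethyl in place of hydroxy on a saturated chain carbon, two bonds along the chain from an aromatic nitrogen.

Among the compounds with values here, no step between measured compounds is available to guide the estimate, and the three numbers in hand show no spread beyond the scatter. The expectation for compound 4 is therefore a step of a 1.0-fold lower number from compound 1 to compound 4 (0.02 log units; within the scatter) that does not exceed the scatter in either direction. Compound 4 is expected to give about 0.5 h, with a likely range from 0.3 h to 0.85 h.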

Compound 4, half-life: 0.332 h
Beside the measured number, compound 4's estimate is 1.5-fold (0.18 log units) above it; the measured number falls inside the stated range.
By their numbers in this assay, from the lowest: compounds 4, 2, 1 and 3 (each within the scatter of the next).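

Within the data shown here, compound 4 gives the first comparison at this position that differs in one place only: in this assay, hydroxymethyl in place of hydroxy on a saturated chain carbon, two bonds along the chain from an aromatic nitrogen, gives a 1.6-fold lower number from compound 1 to compound 4 (0.19 log units; within the scatter). On this one pair, then, the half-life of the 3-hydroxypropyl compound cannot be told apart from that of the 2-hydroxyethyl compound, and a single added chain carbon produces no step beyond the scatter. No supporting measurement bears on this step.

As far as these compounds go, whether a longer chain than 3-hydroxypropyl, or an amine or a carboxylic acid in place of the hydroxy at the chain end, would take the half-life beyond the scatter remains open. One pair also cannot show whether the same extension would read alike with other groups on the shared core.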